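A few compounds are considered here, and "the series" means these few. Any claim that something is new, unique, unknown or untested is made for them only; others in the source may bear on it.

Measured in a functional assay on MGC-803 cells (Homo sapiens) for antiproliferative activity, read by MTT assay, with a stated time of 48 h; on this read-out lower numbers stand for stronger inhibition and higher numbers for weaker inhibition:
- compound 1 `CCCCCCCCn1cc(COC[C@@H]2OC[C@H](N)[C@@H]2O)nn1`: 70400 nM
- compound 2 `CCCCCCCCCn1cc(COC[C@@H]2OC[C@H](N)[C@@H]2O)nn1`: 13800 nM
- compound 3 `CCCCCCCCCCCCn1cc(COC[C@@H]2OC[C@H](N)[C@@H]2O)nn1`: 21400 nM

Compound 1 has the highest number of the three and is therefore the weakest inhibitor here. Both other compounds lie clearly lower, as shown by a 5.1-fold lower number from compound 1 to compound 2 (0.71 log units; beyond the scatter) and a 3.3-fold lower number from compound 1 to compound 3 (0.52 log units; beyond the scatter). Those two steps change only the length of the chain on the aromatic nitrogen. The remaining chain step, a 1.6-fold higher number from compound 2 to compound 3 (0.19 log units; within the scatter), is too small to separate compound 2 from compound 3.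

Compound 4 `CCCCCCCCn1cc(COC[C@@H]2OC[C@H](N)[C@H]2O)nn1` leaves that chain as it is in compound 1. The change is the two compounds have the same atoms and bonds and differ only in configuration as drawn: 1 of 3 stereo elements differ; a stereocentre at a saturated ring carbon is drawn S in compound 1 and R in compound 4, and a stereocentre at a saturated ring carbon is drawn S in compound 1 and R in compound 4. Among the measured compounds shown here, no measured pair differs in this way, so the chain steps say nothing direct about its size or direction. They only show that the numbers in this small set have moved by modest amounts. With no evidence for a direction, no step beyond the scatter is expected, though a larger one in either direction cannot be ruled out. The expected change is a 1.2-fold lower number from compound 1 to compound 4 (0.07 log units; within the scatter). For compound 4 the estimated value is 60000 nM, with an expected range from 20000 nM to 180000 nM.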

Compound 4, half-maximal inhibitory concentration: > 128000 nM
Compound 4: only a limit was reported (the forecaster's own chance of this, stated with the estimate: 15%); middle value at least 2.1-fold (0.32 log units) from the limit.
By their numbers in this assay, from the lowest: compounds 2 and 3 (each within the scatter of the next); then compound 1. At a limit, above all of these: compound 4.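

In this assay compound 4 gave only a limit, not a number: the limit of > 128000 nM in this assay, at which 1 of the 4 values shown sits. Even so, the step, an at least 1.8-fold higher number from compound 1 to compound 4 (0.25 log units; that floor lies within the scatter), shows that this change of configuration brought no lower number, although its floor alone does not establish a change beyond the usual scatter, and the real gap remains unknown. The earlier compounds shown here changed only the chain on the aromatic nitrogen, whereas here that chain stays fixed and the comparison turns to a stereocentre at a saturated ring carbon, with one thing alone separating the pair: the fact that compounds 1 and 4 differ only in the configuration as drawn.

On these data alone, it remains open how far the true number of compound 4 lies from that of compound 1, and whether the R configuration at this carbon would have a similar effect on the longer chains of compound 2 and compound 3. The compounds shown also leave open how the read-out would respond to a carboxylic acid in place of the amine, or to a chain longer than that of compound 3.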